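The compounds below may be only part of what the source reports. "The series", "measured", "known", "first", "only" and "open" are said of these compounds alone.

Working notes on the series, read in a functional assay on NCI-H460 cells (Homo sapiens) for cytotoxicity, read by sulforhodamine B assay, with a stated time of 24 h; a higher number here means a weaker inhibitor, a lower number a stronger inhibitor. Compound 1 `O=C(CCCC(c1c[nH]c2ccccc12)c1c[nH]c2ccccc12)NO` returns only a limit in this assay, > 20000 nM. Compound 2 `O=C(CCCCC(c1c[nH]c2ccccc12)c1c[nH]c2ccccc12)NO`, which carries (hydroxycarbamoyl)methyl in place of hydroxycarbamoyl on a saturated chain carbon, four bonds along the chain from two aromatic carbons, gives 5200 nM in this assay. That change is an at least 3.8-fold lower number from compound 1 to compound 2 (0.58 log units; beyond the scatter). Among the measured compounds shown here, compound 2 therefore holds the only number in this assay; the remaining entry is the limit of > 20000 nM in this assay, at which 1 of the 2 values shown sits. Compound 3 `O=C(CCCCCc1c[nH]c2ccccc12)NO` differs from compound 2 by hydrogen in place of 1H-indol-3-yl on a saturated chain carbon bound to an aromatic carbon and a saturated chain carbon. For the measured compounds named here, no measured step touches this change: the single measured step concerns the length of the chain, not the removal of one 1H-indol-3-yl, so it gives no direct guide to the direction or size of this step in this assay. The working estimate for compound 3 in this assay is 12000 nM, with a range of 4000 nM to 40000 nM. The expected step is thus a 2.3-fold higher number from compound 2 to compound 3 (0.36 log units; beyond the scatter), with a fair chance that only a limit is returned.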

Compound 3, half-maximal inhibitory concentration: 22000 nM
Estimate against measurement, compound 3: 1.8-fold (0.26 log units) below, and the stated range covers the measured number.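

Among the compounds shown here, compound 3 gives the first measured change at the saturated chain carbon bound to an aromatic carbon and a saturated chain carbon, whereas the earlier step concerned only the length of the chain. With hydrogen in place of one 1H-indol-3-yl, this assay shows a 4.2-fold higher number from compound 2 to compound 3 (0.63 log units; beyond the scatter), so the second 1H-indol-3-yl carries a modest part of the activity of compound 2 in this comparison. Compound 1 remains a limit and not a number: the limit of > 20000 nM in this assay, at which 1 of the 3 values shown sits.

Open, going by these compounds, is whether phenyl or an amine at this carbon would match the 1H-indol-3-yl of compound 2. Also open, on these data alone, is whether a longer chain would lower the number further, with one 1H-indol-3-yl or with two.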